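This account rests on a few compounds, and the source may have more. Where it says the series, first, only, none or still open, it means among the compounds named here.

Compound 2 `CC(=O)c1c(NNc2ccc(Br)cc2)cc(C)oc1=O` stands lowest of the two compounds measured in a functional assay on the whole organism for inhibition, with Rattus norvegicus as the target, read by paw edema, with a stated time of 1 h, at a dose of 50 mg/kg (on this read-out lower numbers stand for less inhibition and higher numbers for more inhibition at the one dose given (going by the name of the read-out)), where compound 2 gives 46.8%. Going by the values given here, compound 1 `CC(=O)c1c(NNc2ccc(C)cc2)cc(C)oc1=O` gives 60.1% in this assay, and the one measured step, a number 13.3 percentage points lower from compound 1 to compound 2 (beyond the scatter), is the only comparison at hand. Compound 3 `COc1ccc(NNc2cc(C)oc(=O)c2C(C)=O)cc1` differs from compound 2 by methoxy in place of bromo on an aromatic carbon. Among the compounds with values here, no measured step swaps bromo for methoxy, so the expectation rests on compound 2 at 46.8% and on that single step. A modest step upward is expected, a number 7.2 percentage points higher from compound 2 to compound 3 (within the scatter), though it may fall within the scatter. Compound 3 is expected to give 54%, between 38% and 70%.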

Compound 3, a percentage reported as inhibition, in the whole organism at one dose (the size of the read-out at that dose, not a potency): 50%
Estimate against measurement, compound 3: 4 percentage points above; measured number inside the range.
By their numbers in this assay, from the lowest: compounds 2 and 3 (each within the scatter of the next); then compound 1.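

Swapping bromo for methoxy on this aromatic carbon, para to a large group, gives a number 3.2 percentage points higher from compound 2 to compound 3 (within the scatter), so these two groups cannot be told apart here. Methoxy in place of methyl gives a number 10.1 percentage points lower from compound 1 to compound 3 (beyond the scatter), so among these three groups, methyl alone stands apart, with bromo and methoxy both giving lower numbers. Nothing at hand explains this difference. On these data alone, whether an amine, a carboxylic acid or a longer chain at this position would match or pass compound 1 remains open. So does the outcome of leaving a plain hydrogen there.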